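Fluoro for methoxy in a two-compound series

This account rests on a few compounds, and the source may have more. Where it says the series, first, only, none or still open, it means among the compounds named here.

Measured in a functional assay on LoVo cells (Homo sapiens) for inhibition, read by colorimetric assay and MTT assay, with a stated time of 72 h (on this read-out lower numbers stand for stronger inhibition and higher numbers for weaker inhibition), so far:
- compound 1 `C=CCCCCOc1ccc(C)cc1-c1cnc(OCCC=C)n1C` gives 41000 nM
- compound 2 `C=CCCCCOc1ccc(OC)cc1-c1cnc(OCCC=C)n1C` gives 33000 nM

Compound 2 stands within the scatter of compound 1, so the two numbers give no ranking. Compound 3 `C=CCCCCOc1ccc(F)cc1-c1cnc(OCCC=C)n1C` differs from compound 2 by fluoro in place of methoxy on an aromatic carbon in one place: fluoro in place of methoxy on an aromatic carbon, para to a (hex-5-en-1-yl)oxy group. Going by the values given here, the only measured step at this carbon (a 1.2-fold lower number from compound 1 to compound 2 (0.09 log units; within the scatter)) lies within the scatter, so no step beyond the scatter is expected in this assay for this change. The estimated step (a 1.2-fold higher number from compound 2 to compound 3 (0.06 log units; within the scatter)) stays inside that scatter. For compound 3 the estimate is 38000 nM with an expected range from 18000 nM to 80000 nM for a measurement.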

Compound 3, half-maximal inhibitory concentration: 38000 nM
Compound 3: middle estimate and measured number agree at the digits printed; the measured number falls inside the stated range.
By their numbers in this assay, from the lowest: compounds 2, 3 and 1 (each within the scatter of the next).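

At the aromatic carbon para to the (hex-5-en-1-yl)oxy group, a third substituent gives the same flat picture in this assay: a 1.2-fold higher number from compound 2 to compound 3 (0.06 log units; within the scatter) and a 1.1-fold lower number from compound 1 to compound 3 (0.03 log units; within the scatter) both lie within the scatter. Methyl, methoxy and fluoro therefore cannot be told apart here, and replacing methoxy with fluoro, which removes one hydrogen-bond acceptor, does not separate compound 3 from compound 2. From the compounds shown here alone, whether an amine, a carboxylic acid or a longer chain at this carbon would give a step beyond the scatter stays open. So does the effect of changing the (hex-5-en-1-yl)oxy group itself, and no supporting data bear on this result.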